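The source may hold more compounds than are shown below. What is called first, only, known or untested is meant among the compounds shown, and "the series" means these compounds.

Compound 1 `Cn1ccc2ccc(-c3cc(Nc4ccccc4S(N)(=O)=O)cc4nccnc34)cc21`: 265 nM
Compound 2 `CN(C)S(=O)(=O)c1ccccc1Nc1cc(-c2ccc3ccn(C)c3c2)c2nccnc2c1`: 94 nM
Compound 3 `Cn1cc(CNS(=O)(=O)c2ccccc2Nc2cc(-c3ccc4ccn(C)c4c3)c3nccnc3c2)cn1`: 38 nM

Of the compounds shown here, three built on one shared core have been tested in an assay for inhibition of 6-phosphofructo-2-kinase/fructose-2,6-bisphosphatase 3 (Homo sapiens), read by ADP-Glo, with a stated time of 2 h; a higher number here means a weaker inhibitor, a lower number a stronger inhibitor. Compound 2 stands second highest of the three numbers: the move from the plain sulfonamide gives a 2.8-fold lower number from compound 1 to compound 2 (0.45 log units; beyond the scatter), and the further move to the ring-bearing sulfonamide gives a 2.5-fold lower number from compound 2 to compound 3 (0.39 log units; beyond the scatter). Taken together, these two steps add up to a 7.0-fold lower number from compound 1 to compound 3 (0.84 log units; beyond the scatter).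

Compound 4 `Cn1ccc2ccc(-c3cc(Nc4ccccc4S(=O)(=O)NCC4CCOCC4)cc4nccnc34)cc21` has not yet been measured. Against compound 2 the change is ((oxan-4-yl)methyl)amino in place of dimethylamino on a sulfonyl sulfur. The step from compound 2 to compound 3 bears most directly on it. There too a dimethylamino on the sulfonyl sulfur was replaced by a ring-bearing substituent on the sulfonamide nitrogen, and that step was modest but beyond the scatter. A similar modest lowering is expected because a 2.5-fold lower number from compound 2 to compound 3 (0.39 log units; beyond the scatter), so that compound 4 is estimated at 45 nM (range 18 nM to 110 nM), which would mean an expected step of a 2.1-fold lower number from compound 2 to compound 4 (0.32 log units; beyond the scatter).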

Compound 4, half-maximal inhibitory concentration: 26 nM
The estimate for compound 4 lay 1.7-fold (0.24 log units) above the measured number; measured number inside the range.
By their numbers in this assay, from the lowest: compounds 4 and 3 (each within the scatter of the next); then compound 2; then compound 1.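

In this assay, for the compounds shown here, a six-membered non-aromatic ring also lowers the number at this position: ((oxan-4-yl)methyl)amino on the sulfonyl sulfur gives the first step (a 3.6-fold lower number from compound 2 to compound 4 (0.56 log units; beyond the scatter)), and against the plain sulfonamide the change is the only large step in the set (a 10-fold lower number from compound 1 to compound 4 (1.01 log units; beyond the scatter)). The gain seen with compound 3 therefore does not depend on the 1-methyl-1H-pyrazol-4-yl ring, for replacing it with oxan-4-yl leaves the two compounds within the scatter of each other (a 1.5-fold lower number from compound 3 to compound 4 (0.16 log units; within the scatter)). No measurement at hand explains why either ring lowers the number.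

The compounds shown leave open whether the ring oxygen matters, which a cyclohexylmethyl group would test, and how a piperidin-4-ylmethyl group, with an amine in the ring, would compare. They also leave open whether an open hexyl chain could serve in place of a ring.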